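2,4-Dichlorophenyl to 2,4-difluorophenyl on compound 2

The compounds below may be only part of what the source reports. "The series", "measured", "known", "first", "only" and "open" are said of these compounds alone.

Measured so far in a functional assay on SK-OV-3 cells (Homo sapiens); a lower number here means a stronger inhibitor of growth, a higher number a weaker inhibitor of growth:
- compound 1 `O=S(=O)(/C=C/c1ccc(Cl)cc1Cl)Cc1ccc(Nc2ncnc3ccccc23)cc1`: 2000 nM
- compound 2 `O=S(=O)(/C=C/c1ccc(Cl)cc1Cl)Cc1ccc(Nc2ncnc3ccc(Br)cc23)cc1`: 1000 nM

Among the compounds with values here, compound 2, at 1000 nM, lies within the scatter of compound 1, the only other measured compound, so the two cannot be ranked. The next compound is compound 3 `O=S(=O)(/C=C/c1ccc(F)cc1F)Cc1ccc(Nc2ncnc3ccc(Br)cc23)cc1`, and the change is 2,4-difluorophenyl in place of 2,4-dichlorophenyl on a double-bonded chain carbon bound to a double-bonded chain carbon. Within the data shown here, the one measured step is a 2.0-fold lower number from compound 1 to compound 2 (0.30 log units; within the scatter). That step is bromo in place of hydrogen on an aromatic carbon, so it bears only indirectly. Among the measured compounds shown here, no measured pair varies the 2,4-dichlorophenyl group, and the data offer no direct guide to this exchange. No step beyond the scatter is therefore expected in this assay, though the range is kept wide. The expected step is no change at the digits printed from compound 2 to compound 3 (within the scatter). Compound 3 is estimated at 1000 nM, with an expected range of 400 nM to 3000 nM.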

Compound 3, concentration for 50% growth inhibition: 2000 nM
Compound 3: middle estimate off by 2.0-fold (0.30 log units), on the low side; low and high end bracket the measured number.
By their numbers in this assay, from the lowest: compounds 2, 1 and 3 (each within the scatter of the next).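

In this assay, 2,4-difluorophenyl in place of 2,4-dichlorophenyl on a double-bonded chain carbon bound to a double-bonded chain carbon gives a 2.0-fold higher number from compound 2 to compound 3 (0.30 log units; within the scatter) and so cannot be told apart from no effect. This is the only measured variation of this aryl group, and it shows that, with the bromo held constant on the shared core, the two dihalophenyl groups cannot be ranked in this read-out. No supporting measurement accompanies the step, and its origin remains unaddressed.

Still open, going by these compounds, is whether an unsubstituted phenyl, or a methoxy or amine on this ring, would give a step beyond the scatter. Also open, on these data alone, is whether the same exchange reads alike on the core of compound 1, which carries no bromo.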